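Swapping a benzoyl for a pyridinylcarbonyl in cytotoxicity

A few compounds are considered here, and "the series" means these few. Any claim that something is new, unique, unknown or untested is made for them only; others in the source may bear on it.

Measured so far:
compound 1, `Cc1ccc(-c2nn(-c3ccccc3)cc2-c2nc3ccccc3n2C(=O)c2ccccc2)cc1`: 204000 nM
compound 2, `O=C(c1ccccc1)n1c(-c2cn(-c3ccccc3)nc2-c2ccc(F)cc2)nc2ccccc21`: 180000 nM

Both compounds were tested in an ADME assay on HEK-293T cells (Homo sapiens) for cytotoxicity, read by MTT assay, with a stated time of 24 h; on this read-out higher numbers stand for lower toxicity in this test and lower numbers for higher toxicity in this test. Compound 1 gives 204000 nM, the highest of the two numbers, and its nearest neighbour is compound 2 with 180000 nM. The step of a 1.1-fold lower number from compound 1 to compound 2 (0.05 log units; within the scatter) lies within the scatter, so the two compounds cannot be told apart on this read-out.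

Compound 3, `Cc1ccc(-c2nn(-c3ccccc3)cc2-c2nc3ccccc3n2C(=O)c2cccnc2)cc1`, has not yet been measured. It differs from compound 1 in one place: pyridin-3-yl in place of phenyl on a carbonyl carbon. Cut one bond further out, the change reads benzoyl to (pyridin-3-yl)carbonyl.

Going by the values given here, no measured step touches the carbonyl carbon; the only step available, from methyl to fluoro on an aromatic carbon, stayed within the scatter. There is thus no basis in the data for expecting a shift beyond the scatter in either direction. Compound 3 is therefore expected to sit close to compound 1, with the step of a 1.0-fold lower number from compound 1 to compound 3 (0.01 log units; within the scatter) estimated to stay within the scatter. The estimate for compound 3 in this assay is 200000 nM, with a range from 100000 nM to 400000 nM.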

Compound 3, half-maximal cytotoxic concentration: 189000 nM
Estimate against measurement, compound 3: 1.1-fold (0.02 log units) above; measured number inside the range.
By their numbers in this assay, from the lowest: compounds 2, 3 and 1 (each within the scatter of the next).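

In this assay the step at the carbonyl carbon is a 1.1-fold lower number from compound 1 to compound 3 (0.03 log units; within the scatter), and it lies within the scatter, so compound 3 cannot be told apart from compound 1 on this read-out. Going by these compounds alone, the earlier pair only tested a change on an aromatic carbon, whereas this result is the first reading for the carbonyl carbon: here a six-membered aromatic ring with one nitrogen and one hydrogen-bond acceptor stands in place of an all-carbon ring, with no change that can be read in this test. No measurement shown here offers an explanation for this result.

The compounds shown leave open whether a different group on the same carbonyl carbon, such as pyridin-4-yl, a phenyl ring carrying an amine or a carboxylic acid, or a plain alkyl chain in place of the ring, would also stay within the scatter of compound 1. They also leave open whether pyridin-3-yl at this place would give the same result when paired with the fluoro substituent of compound 2.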